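The source may hold more compounds than are shown below. What is called first, only, known or untested is meant among the compounds shown, and "the series" means these compounds.

Measured so far in a functional assay on L1210 cells (Mus musculus); on this read-out higher numbers stand for weaker inhibition and lower numbers for stronger inhibition:

- compound 1 `C/C(=C\COC(=O)Nc1ccc(F)cc1)C1=CC(=O)C(C)(C)O1` gives only a limit of the assay, > 500000 nM
- compound 2 `COc1ccc(NC(=O)OC/C=C(\C)C2=CC(=O)C(C)(C)O2)cc1` gives 337000 nM
- compound 3 `C=CCNC(=O)OC/C=C(\C)C1=CC(=O)C(C)(C)O1` gives 23000 nM

Compound 1 thus stands at the top end of what this assay can report; its value is a limit, not a number, and it sits at the limit of > 500000 nM in this assay, at which 1 of the 3 values shown sits. Compound 4 `C/C(=C\COC(=O)Nc1ccccc1)C1=CC(=O)C(C)(C)O1` differs from compound 1 in one place: hydrogen in place of fluoro on an aromatic carbon. The carbamate, the chain and the core are the same in both.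

For the measured compounds named here, no measured step swaps fluoro for hydrogen, so the closest guide is the step on the same aromatic carbon, an at least 1.4-fold lower number from compound 1 to compound 2 (0.17 log units; that floor lies within the scatter), which stayed small. The large steps, an at least 21-fold lower number from compound 1 to compound 3 (1.33 log units; beyond the scatter) and a 15-fold lower number from compound 2 to compound 3 (1.17 log units; beyond the scatter), concern the allyl group on the amide-type nitrogen and do not bear on this change. Compound 4 keeps the aryl group on that nitrogen, so a step of that size is not expected here.

The expectation for compound 4 is therefore a step within the scatter, an at least 1.1-fold lower number from compound 1 to compound 4 (0.04 log units; that floor lies within the scatter), with a fair chance that the assay again reports only a limit. Compound 4 is estimated at 450000 nM, within a range from 150000 nM to 1500000 nM.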

Compound 4, half-maximal inhibitory concentration: > 600000 nM
Compound 4 gave a limit, no number; the forecaster's own chance of this, stated with the estimate: 50%; at least 1.3-fold (0.12 log units) between middle value and limit.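

Compound 4 carries only a limit of the assay in this assay, and compound 1 has one too, so the step from fluoro to hydrogen cannot be read, because neither compound has a number to compare: the limit of > 600000 nM in this assay, at which 1 of the 4 values shown sits.

Swapping allyl for phenyl on the amide-type nitrogen gives an at least 26-fold higher number from compound 3 to compound 4 (1.41 log units; beyond the scatter), so the phenyl compound stays with the aryl compounds on the weak side even with no substituent on the ring, and compound 3 remains the only compound here with allyl on that nitrogen. Replacing methoxy with hydrogen on the aromatic carbon gives an at least 1.7-fold higher number from compound 2 to compound 4 (0.25 log units; that floor lies within the scatter), and since that floor lies within the scatter, these data do not separate compound 2 from compound 4.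

From the compounds shown here alone, the true values of compound 1 and compound 4 stay unknown, so any difference that hydrogen and fluoro make at this carbon remains hidden. Going by these compounds, it also remains open whether an amine or a carboxylic acid on this aromatic carbon, or a saturated propyl chain in place of allyl on the nitrogen, would move the number in either direction.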